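Trifluoromethyl to Methoxy: Expected Shift in Cell Potency

A few compounds are considered here, and "the series" means these few. Any claim that something is new, unique, unknown or untested is made for them only; others in the source may bear on it.

compound 1 `COc1ccc(-c2ccnc(C(=O)Nc3ccc(Oc4ccnc5cc(OCCCN6CCCCC6)c(OC)cc45)c(F)c3)c2)cc1`: 690 nM
compound 2 `COc1cc2c(Oc3ccc(NC(=O)c4cc(-c5ccc(C(F)(F)F)cc5)ccn4)cc3F)ccnc2cc1OCCCN1CCN(C)CC1`: 200 nM

In a functional assay on HT-29 cells (Homo sapiens) for cytotoxicity, read by MTT assay, with a stated time of 72 h (on this read-out lower numbers stand for stronger inhibition and higher numbers for weaker inhibition), compound 2 gives the lower of the two numbers, and compound 1 gives a higher one, a gap beyond the usual scatter. Compound 3 `COc1ccc(-c2ccnc(C(=O)Nc3ccc(Oc4ccnc5cc(OCCCN6CCN(C)CC6)c(OC)cc45)c(F)c3)c2)cc1` differs from compound 2 in one place: methoxy in place of trifluoromethyl on an aromatic carbon. Within the data shown here, compound 1 carries the same methoxy but also a different amine-containing chain, so no single-change step is available. For compound 3 a modest weakening is expected, a step of a 2.5-fold higher number from compound 2 to compound 3 (0.40 log units; beyond the scatter), since compound 1 bearing the methoxy gives 690 nM in this assay. Compound 3 is therefore estimated at 500 nM, within a range from 200 nM to 1500 nM.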

Compound 3, half-maximal inhibitory concentration: 390 nM
Estimate against measurement, compound 3: 1.3-fold (0.11 log units) above, and the stated range covers the measured number.
By their numbers in this assay, from the lowest: compounds 2, 3 and 1 (each within the scatter of the next, the first and the last beyond it).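

In this assay, methoxy in place of trifluoromethyl para to a large group gives a 2.0-fold higher number from compound 2 to compound 3 (0.29 log units; within the scatter), so this assay does not separate 4-methoxyphenyl from 4-(trifluoromethyl)phenyl. The amine can now be read on its own as well: 4-methylpiperazin-1-yl in place of piperidin-1-yl gives a 1.8-fold lower number from compound 1 to compound 3 (0.25 log units; within the scatter), so these two amines are not separated either. No measurement is available to explain either result.

Still open, on these data alone, is whether a chlorine or a carboxylic acid on this aromatic carbon would shift the number beyond the scatter. The same question stands for a morpholine or a longer chain carrying the amine.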